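This account rests on a few compounds, and the source may have more. Where it says the series, first, only, none or still open, it means among the compounds named here.

In a functional assay on MCF7 cells (Homo sapiens) for inhibition, read by MTT assay, with a stated time of 72 h (on this read-out higher numbers stand for weaker inhibition and lower numbers for stronger inhibition), compound 2 `Cc1cc(Nc2cc(-c3cccs3)[nH]n2)n2nc(SCc3ccc(Br)cc3)nc2n1` gives 5370 nM, the highest of the two numbers shown, though the nearest, compound 1 `Cc1cc(Nc2cc(-c3ccccc3)[nH]n2)n2nc(SCc3ccc(F)cc3)nc2n1` at 4020 nM, lies within the scatter of it. For compound 3 `Cc1cc(Nc2cc(-c3ccccc3)[nH]n2)n2nc(SCC3CC3)nc2n1` the assay reports only a limit, > 50000 nM. Going by the values given here, the one measured step, an at least 12-fold higher number from compound 1 to compound 3 (1.09 log units; beyond the scatter), sits on the sulfur-bound chain at the other side of the shared core and is bounded by the limit of > 50000 nM in this assay, at which 1 of the 3 values shown sits. Compound 4 `Cc1cc(Nc2cc(C(C)(C)C)[nH]n2)n2nc(SCc3ccc(Br)cc3)nc2n1` differs from compound 2 by tert-butyl in place of thiophen-2-yl on an aromatic carbon. Among the compounds with values here, no measured step touches this position, so the expectation leans only loosely on it: because an at least 12-fold higher number from compound 1 to compound 3 (1.09 log units; beyond the scatter) traded an aromatic ring for a saturated group and lost much, a weaker result is expected for compound 4, namely a 2.2-fold higher number from compound 2 to compound 4 (0.35 log units; beyond the scatter). Compound 4 is therefore estimated at 12000 nM, between 4000 nM and 40000 nM.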

Compound 4, half-maximal inhibitory concentration: 7290 nM
Beside the measured number, compound 4's estimate is 1.6-fold (0.22 log units) above it; the range from low to high includes it.
By their numbers in this assay, from the lowest: compounds 1, 2 and 4 (each within the scatter of the next). At a limit, above all of these: compound 3.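

In this assay, the exchange of thiophen-2-yl for tert-butyl on this aromatic carbon gives a 1.4-fold higher number from compound 2 to compound 4 (0.13 log units; within the scatter). Going by these compounds alone, this is the first measured step at this position, and it shows that a group with no ring can stand here in place of the five-membered aromatic ring with no change beyond the scatter, unlike the large step on the sulfur-bound chain. Nothing measured here gives a reason for this result. On these data alone, how an amine, a carboxylic acid or a longer chain on this carbon would read out remains open.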